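The source may report more compounds than this note shows. Statements on the series, on what has been measured and on what is new or still open speak of the compounds shown alone.

Compound 1 `Fc1cccc(F)c1Cn1c(-c2c(F)cccc2F)nc2c(Br)cccc21` gives 24.5 uM in a toxicity assay on CCRF-CEM cells (Homo sapiens) for cytotoxicity; a higher number here means that more compound is tolerated, a lower number that less compound is tolerated. Compound 2 `N#Cc1cccc2c1nc(-c1c(F)cccc1F)n2Cc1c(F)cccc1F` gives 26.7 uM in this assay. Compound 3 `NC(=O)c1cccc2c1nc(-c1c(F)cccc1F)n2Cc1c(F)cccc1F` gives > 100 uM in this assay, which is a limit of the assay and not a number.

Compound 2 stands at one of only two numbers shown, with compound 1 alongside it at a 1.1-fold higher number from compound 1 to compound 2 (0.04 log units; within the scatter). Compound 4 `NCc1cccc2c1nc(-c1c(F)cccc1F)n2Cc1c(F)cccc1F` differs from compound 2 by aminomethyl in place of cyano on an aromatic carbon. The measured steps at the same position are an at least 3.7-fold higher number from compound 2 to compound 3 (0.57 log units; beyond the scatter) and an at least 4.0-fold higher number from compound 1 to compound 3 (0.61 log units; beyond the scatter); both end at the limit (the limit of > 100 uM in this assay, at which 1 of the 3 values shown sits). The aminomethyl group, like the carbamoyl group, brings a hydrogen-bond donor, so a higher number is expected, about a 2.1-fold higher number from compound 2 to compound 4 (0.31 log units; beyond the scatter). Compound 4 is therefore expected to give 55 uM, within 22 uM to 140 uM.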

Compound 4, half-maximal toxic concentration: 49.3 uM
Compound 4: the middle estimate sits 1.1-fold (0.05 log units) above what was measured; the measured number falls inside the stated range.
By their numbers in this assay, from the lowest: compounds 1, 2 and 4 (each within the scatter of the next). At a limit, above all of these: compound 3.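

In this assay, for the compounds shown here, aminomethyl is the first group at this position with a hydrogen-bond donor to give a number and not a limit, and that number stays within the scatter of those for cyano and bromo: a 1.8-fold higher number from compound 2 to compound 4 (0.27 log units; within the scatter), and a 2.0-fold higher number from compound 1 to compound 4 (0.30 log units; within the scatter). A hydrogen-bond donor at this position therefore does not by itself set a compound apart from compound 1 or compound 2. The comparison with carbamoyl gives only a floor, an at least 2.0-fold lower number from compound 3 to compound 4 (0.30 log units; that floor lies within the scatter), and it rests on a limit: the limit of > 100 uM in this assay, at which 1 of the 4 values shown sits.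

On these data alone, whether compound 3 truly stands apart from compound 4 stays open. So does what a carboxylic acid or a longer aminoethyl chain would give at this position.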